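The compounds below may be only part of what the source reports. "The series", "measured", "known", "first", "only" and "open" are said of these compounds alone.

Measured compounds in the series:

compound 1, `ClCc1ccccc1Cn1cnc2c(Cl)nc(Cl)nc21` — 720 nM
compound 2, `ClCc1ccccc1Cn1cnc2c(Cl)ncnc21` — 3380 nM
compound 3, `ClCc1cccc(Cn2cnc3c(Cl)nc(Cl)nc32)c1` — 2130 nM

All three were run in a functional assay on SN12C cells (Homo sapiens) for cytotoxicity, read by sulforhodamine B assay, with a stated time of 48 h; on this read-out higher numbers stand for weaker inhibition of growth and lower numbers for stronger inhibition of growth. Compound 2 gives the highest number of the three; compound 3 sits within the scatter of it, while compound 1 lies beyond the scatter on the lower side. Going by the values given here, the only single-point step measured so far, a 4.7-fold higher number from compound 1 to compound 2 (0.67 log units; beyond the scatter), shows that a substituent on that carbon of the shared core carries weight in this assay.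

Compound 4, `Nc1nc(Cl)c2ncn(Cc3ccccc3CCl)c2n1`, has not been measured. It differs from compound 2 by amino in place of hydrogen on an aromatic carbon. Among the compounds with values here, no measured step places an amino group on that carbon; the step that bears on it is a 4.7-fold higher number from compound 1 to compound 2 (0.67 log units; beyond the scatter), and it concerns a chloro group rather than an amino group. On that basis, restoring a substituent at the carbon that is bare in compound 2 is expected to move the number downward, though with wide uncertainty. In this assay the expected step is a 1.5-fold lower number from compound 2 to compound 4 (0.19 log units; within the scatter), a modest movement. Compound 4 is estimated at 2200 nM, with a range from 700 nM to 7000 nM.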

Compound 4, concentration for 50% growth inhibition: 2750 nM
The estimate for compound 4 lay 1.3-fold (0.10 log units) below the measured number; the measured number falls inside the stated range.
By their numbers in this assay, from the lowest: compound 1; then compounds 3, 4 and 2 (each within the scatter of the next).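

In this assay, amino in place of hydrogen at this carbon between two ring nitrogen atoms gives a 1.2-fold lower number from compound 2 to compound 4 (0.09 log units; within the scatter), while amino in place of chloro gives a 3.8-fold higher number from compound 1 to compound 4 (0.58 log units; beyond the scatter). A substituent on this carbon is therefore not enough in itself to give the lower number: hydrogen and amino cannot be told apart here, and chloro alone stands apart from both. Nothing available accounts for this difference between chloro and amino.

As far as these compounds go, it remains open whether the lower number is confined to chloro or also appears with bromo, methyl or methoxy at this carbon. The compounds shown also leave open whether amino and chloro would compare in the same way on the scaffold of compound 3.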